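The source may report more compounds than this note shows. Statements on the series, on what has been measured and on what is new or still open speak of the compounds shown alone.

Working notes on the series, all read in a functional assay on NCI-H460 cells (Homo sapiens) for inhibition, read by MTT assay, with a stated time of 24 h, tested at 0.1 ug/mL (a lower number here means less inhibition of growth, a higher number more inhibition of growth at the concentration tested), only. Compound 1 (`O=C(O)CCCCC(CCSC(=O)c1ccccc1)SC(=O)c1ccccc1`) is recorded as "not active" (no number reported) and offers no number for comparison. Compound 2 (`O=C(CCCCC(S)CCS)NO`) gives 5.7% in this series, and compound 3 (`COc1ccc(NC(=O)CCCCC(S)CCS)cc1`) gives 5.69% in the same read-out. These two numbers lie within the scatter of each other, so compound 2 stands level with compound 3 and no order can be drawn between them.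

The next entry is compound 4 (`O=C(CCCCC(S)CCS)Nc1ccccn1`), still unmeasured. Relative to compound 2, it carries pyridin-2-yl in place of hydroxy on an amide-type nitrogen.

Within the data shown here, no measured step gives a size for this change. Among the measured compounds shown here, the only numerical guide is that compound 3 at 5.69% sits within the scatter of compound 2 at 5.7% in these notes. In this assay no step beyond the scatter is therefore expected, in either direction, although a result without a number, as for compound 1, remains possible. The expected step (a number 1.3 percentage points higher from compound 2 to compound 4 (within the scatter)) stays within the scatter. For compound 4 the estimated value is 7% with an expected range from 1% to 18% on measurement.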

Compound 4, percent growth inhibition at one concentration: 5.01%
Compound 4: the middle estimate sits 2 percentage points above what was measured; low and high end bracket the measured number.
By their numbers in this assay, from the lowest: compounds 4, 3 and 2 (each within the scatter of the next).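

In this assay, the amide-type nitrogen now has its first measured step: pyridin-2-yl in place of hydroxy gives a number 0.7 percentage points lower from compound 2 to compound 4 (within the scatter). This exchange is not a small one in the counts, with 6 heavy atoms and a six-membered aromatic ring with 1 hetero atom entering for 1 heavy atom and no ring, and with 1 hydrogen-bond donor leaving and 0 entering, yet the step stays within the scatter at the concentration tested. No measurement at hand offers an explanation for this result.

Among these compounds, still open is whether another group on this nitrogen, such as a benzyl group or a longer alkyl chain, would give a step beyond the scatter in this assay, since hydroxy and pyridin-2-yl are the only pair here with a measured step. Also open, going by these compounds, is whether compound 2 and compound 4 would separate at a higher concentration, as a single concentration gives no full response curve for either of them.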